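A few compounds are considered here, and "the series" means these few. Any claim that something is new, unique, unknown or untested is made for them only; others in the source may bear on it.

Working notes on the series

Within the data shown here, compound 1 `CCS(=O)(=O)N(Cc1cccnc1)c1cccc(C(O)c2ccccc2)c1` is the stronger-looking of the two measured members only on paper: in an assay on isolated protein with metabotropic glutamate receptor 2 (Homo sapiens) as the target (on this read-out lower numbers stand for an effect already at smaller amounts and higher numbers for an effect only at larger amounts of compound), compound 1 gives 2500 nM, the lowest of the two numbers recorded, while compound 2 `CCS(=O)(=O)N(Cc1cccnc1)c1ccc(C(=O)c2ccccc2)cc1` in this assay gives 4200 nM. The two values sit within the usual scatter of each other, so no order between compound 1 and compound 2 can be read from them; the two structures also differ in more than one place, so nothing is computed for that pair.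

The step under consideration leads from compound 1 to compound 3 `CCS(=O)(=O)N(Cc1cccnc1)c1cccc(C(=O)c2ccccc2)c1`, not yet measured in this assay. The change is benzoyl in place of hydroxy(phenyl)methyl on an aromatic carbon, meta to a large group. Compound 2 carries the same benzoyl group on the shared core at another position and its value stays within the scatter of compound 1, which gives no basis for expecting a step beyond the scatter here.

For compound 3 the expected step from compound 1 to compound 3 is therefore a 1.2-fold higher number from compound 1 to compound 3 (0.08 log units; within the scatter), essentially none beyond the scatter. Compound 3 is estimated at 3000 nM in this assay, with a range from 1000 nM to 9000 nM.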

Compound 3, half-maximal effective concentration: 1100 nM
The estimate for compound 3 lay 2.7-fold (0.44 log units) above the measured number; the measured number falls inside the stated range.
By their numbers in this assay, from the lowest: compound 3; then compounds 1 and 2 (each within the scatter of the next).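

In this assay, among these compounds, benzoyl in place of hydroxy(phenyl)methyl on this aromatic carbon, meta to a large group, gives a 2.3-fold lower number from compound 1 to compound 3 (0.36 log units; beyond the scatter) and is the first difference that stands beyond the scatter, though only a modest one. The two groups have the same count of heavy atoms and hydrogen-bond acceptors, so the pair differs in the hydrogen-bond donor of hydroxy(phenyl)methyl and the double bond outside aromatic rings of benzoyl, and this single step cannot separate those two differences. No measurement at hand indicates what lies behind the shift in the number.

With benzoyl at another position on the shared core, compound 2 gives 4200 nM while compound 3 gives 1100 nM at this one, but two values do not establish how the number depends on position across the ring. Also open, on these data alone, is whether the number at this position holds or moves further with an amine, an amide or a plain methylene in place of the carbonyl, or with a fluoro group on the phenyl ring of benzoyl.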